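Para substituent variation on the shared core, HeLa growth

The source may hold more compounds than are shown below. What is called first, only, known or untested is meant among the compounds shown, and "the series" means these compounds.

Measured compounds:
compound 1 `O=C(NCc1cn(Cc2ccc(Cl)cc2)nn1)c1cn(-c2ccccc2)nc1-c1ccccc1` gives 600 nM
compound 2 `O=C(NCc1cn(Cc2ccc(Cl)cc2)nn1)c1cn(-c2ccccc2)nc1-c1ccc(F)cc1` gives 210 nM
compound 3 `O=C(NCc1cn(Cc2ccc(Cl)cc2)nn1)c1cn(-c2ccccc2)nc1-c1ccc(Cl)cc1` gives 470 nM

All three numbers come from a functional assay on HeLa cells (Homo sapiens) for antiproliferative activity, read by sulforhodamine B assay, with a stated time of 48 h; a lower number here means a stronger inhibitor of growth, a higher number a weaker inhibitor of growth. Compound 3 stands second highest of the three; its nearest neighbour is compound 1, with a 1.3-fold lower number from compound 1 to compound 3 (0.11 log units; within the scatter), so the two cannot be separated, while the furthest is compound 2, with a 2.2-fold higher number from compound 2 to compound 3 (0.35 log units; beyond the scatter).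

Compound 4 `COc1ccc(-c2nn(-c3ccccc3)cc2C(=O)NCc2cn(Cc3ccc(Cl)cc3)nn2)cc1` differs from compound 3 in one place: methoxy in place of chloro on an aromatic carbon. For the measured compounds named here, no measured pair exchanges chloro for methoxy, so there is no direct precedent for this step. What the series does show at this position is that swapping the substituent moves the number only modestly: a 2.9-fold lower number from compound 1 to compound 2 (0.46 log units; beyond the scatter), a 1.3-fold lower number from compound 1 to compound 3 (0.11 log units; within the scatter) and a 2.2-fold higher number from compound 2 to compound 3 (0.35 log units; beyond the scatter). The three measured compounds lie close together, and the unsubstituted and chloro variants are indistinguishable.

On that basis a small step is expected for compound 4, a 1.3-fold lower number from compound 3 to compound 4 (0.13 log units; within the scatter), most likely not beyond the scatter and, if anything, toward a lower number as seen for the fluoro variant. Compound 4 is therefore estimated at 350 nM, with a range from 120 nM to 1000 nM.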

Compound 4, concentration for 50% growth inhibition: 6400 nM
The estimate for compound 4 lay 18-fold (1.26 log units) below the measured number; the measured number lies above the stated range.
By their numbers in this assay, from the lowest: compound 2; then compounds 3 and 1 (each within the scatter of the next); then compound 4.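

In this assay, for the compounds shown here, the change from 4-chlorophenyl to 4-methoxyphenyl gives the first large step at this position: a 14-fold higher number from compound 3 to compound 4 (1.13 log units; beyond the scatter). The loss is not tied to chloro as the group replaced, since the other two comparisons run the same way, with a 30-fold higher number from compound 2 to compound 4 (1.48 log units; beyond the scatter) and an 11-fold higher number from compound 1 to compound 4 (1.03 log units; beyond the scatter), so methoxy stands apart from hydrogen, fluoro and chloro here, and the position does not accept every substituent with only a modest shift. The computed difference is small, with methoxy bringing two heavy atoms and one hydrogen-bond acceptor where chloro brings one heavy atom and none, and no measurement available here accounts for the size of this step.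

The compounds shown leave open whether the step follows the oxygen, the added carbon or the whole methoxy group, and a hydroxy group or an ethyl group at the same place would help separate these. Going by these compounds, it also remains open how far the loss extends to larger or charged groups, such as an ethoxy group, an amine or a carboxylic acid.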